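Ring size on the side chain, compound 3 to compound 4

The source may hold more compounds than are shown below. What is called first, only, known or untested is meant among the compounds shown, and "the series" means these compounds.

Measured in a functional assay on MCF7 cells (Homo sapiens) for antiproliferative activity, read by CellTiter-Glo, with a stated time of 5 days (a lower number here means a stronger inhibitor, a higher number a weaker inhibitor), as follows

- compound 1 `CC1=C(c2cccc(O)c2)C(c2ccc(OC[C@H](C)N3CCCC3)cc2)Oc2ccc(O)cc21` gives 0.2 nM
- compound 2 `CC1=C(c2cccc(O)c2)C(c2ccc(OC[C@H](C)N3CC[C@@H](C)C3)cc2)Oc2ccc(O)cc21` gives 0.2 nM
- compound 3 `CC1=C(c2cccc(O)c2)C(c2ccc(OC[C@@H](C)N3CC[C@H](C)C3)cc2)Oc2ccc(O)cc21` gives 0.2 nM

Level with compounds 1 and 2, compound 3 stands at 0.2 nM in this assay and has no measured neighbour apart from these two.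

Compound 4 `CC1=C(c2cccc(O)c2)C(c2ccc(OC[C@H](C)N3CCCCCC3)cc2)Oc2ccc(O)cc21` is the next structure to read. The change is a group of 9 heavy atoms (8 carbon, 1 nitrogen; one seven-membered non-aromatic ring with 1 hetero atom) in place of a group of 8 heavy atoms (7 carbon, 1 nitrogen; one five-membered non-aromatic ring with 1 hetero atom), on a saturated chain carbon bound to an oxygen on an aromatic ring and it replaces the five-membered non-aromatic ring with a seven-membered non-aromatic ring.

For the measured compounds named here, three measured steps bear on it. Adding methyl on a saturated ring carbon gave no change at the digits printed from compound 1 to compound 2 (within the scatter) and the group exchange at the same place gave no change at the digits printed from compound 1 to compound 3 (within the scatter) while the change of drawn configuration gave no change at the digits printed from compound 2 to compound 3 (within the scatter) so all three are flat. None of them alters ring size, so the extrapolation is loose and the range is kept wide on the weaker side.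

The expected size of the step is a 1.5-fold higher number from compound 3 to compound 4 (0.18 log units; within the scatter) in this estimate, with nothing beyond the scatter foreseen. For compound 4 the estimated value is 0.3 nM with an expected range of 0.1 nM to 1 nM in this assay.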

Compound 4, half-maximal inhibitory concentration: 0.2 nM
Compound 4: the middle estimate sits 1.5-fold (0.18 log units) above what was measured; the range from low to high includes it.
By their numbers in this assay, from the lowest: compounds 1, 2, 3 and 4 (each within the scatter of the next).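

In this assay, the seven-membered non-aromatic ring in place of the substituted five-membered one gave no change at the digits printed from compound 3 to compound 4 (within the scatter), azepan-1-yl in place of pyrrolidin-1-yl gave no change at the digits printed from compound 1 to compound 4 (within the scatter), and the comparison with the methyl-substituted ring gave no change at the digits printed from compound 2 to compound 4 (within the scatter). For the compounds shown here, the earlier compounds carried only five-membered rings on the side chain, so these steps are the first to show that ring size at this position can change with the value staying within the scatter. The information available gives no explanation for this flat result.

From the compounds shown here alone, whether piperidin-1-yl, an open-chain amine such as dimethylamino, or a carboxylic acid at this position would hold the value remains open. Also open, going by these compounds, is whether azepan-1-yl would do the same with the opposite configuration at the saturated chain carbon.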